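The source may hold more compounds than are shown below. What is called first, only, known or untested is meant among the compounds shown, and "the series" means these compounds.

Compound 1 `COc1ccc(F)cc1CNCCCNc1ccnc2cc(C3CCCCC3)ccc12` is the starting point of this account. In a physicochemical assay for solubility, with a stated time of 18 h, at pH 7.4 (on this read-out higher numbers stand for higher solubility and lower numbers for lower solubility), compound 1 gives 4200 nM. Going by the values given here, its only measured neighbour is compound 2 `COc1ccc(F)cc1CNCCCNc1ccnc2cc(CC(C)C)ccc12`, which in this assay gives 4200 nM; the step of no change at the digits printed from compound 1 to compound 2 (within the scatter) accompanies the exchange of isobutyl in place of cyclohexyl on an aromatic carbon. On the numbers in hand, compound 1 therefore stands level with compound 2, and neither can be called more or less soluble than the other.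

The unmeasured compound 3 `c1coc(CNCCCNc2ccnc3cc(C4CCCCC4)ccc23)c1` departs from compound 1 at a different place: furan-2-yl in place of 5-fluoro-2-methoxyphenyl on a saturated chain carbon bound to an amine nitrogen. Among the compounds with values here, the single measured step, from compound 1 to compound 2, concerns the group on the aromatic carbon of the shared core, not the group on the saturated chain carbon bound to the amine nitrogen, so it offers no direct guide to this change. Within the data shown here, with no step of the same kind to lean on, only a modest movement is expected, and the step is estimated as a 1.4-fold higher number from compound 1 to compound 3 (0.15 log units; within the scatter). Compound 3 is accordingly expected to give about 6000 nM in this assay, within a range of 2500 nM to 15000 nM.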

Compound 3, solubility: 4200 nM
The estimate for compound 3 lay 1.4-fold (0.15 log units) above the measured number; low and high end bracket the measured number.
By their numbers in this assay, from the lowest: compounds 1, 2 and 3 (each within the scatter of the next).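

In this assay, furan-2-yl in place of 5-fluoro-2-methoxyphenyl on a saturated chain carbon bound to an amine nitrogen goes with no change at the digits printed from compound 1 to compound 3 (within the scatter) on this read-out. Going by these compounds alone, this is the first reading at this place, and it shows that a one-ring group of 5 heavy atoms and a one-ring group of 9 heavy atoms, each with 1 hydrogen-bond acceptor, cannot be told apart here, just as isobutyl and cyclohexyl could not be told apart on the aromatic carbon of the shared core. Nothing available explains why this exchange leaves the two compounds level, and no supporting measurement bears on this result.

Still open, going by these compounds, is whether a different kind of group on the same saturated chain carbon, such as a pyridine ring, a piperidine ring or a phenyl ring bearing a carboxylic acid, would separate itself from compound 1 in this read-out. Also open, on these data alone, is whether furan-2-yl would read the same with isobutyl in place of cyclohexyl on the aromatic carbon, so the two exchanges cannot yet be taken as independent of each other.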